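This account rests on a few compounds, and the source may have more. Where it says the series, first, only, none or still open, it means among the compounds named here.

In a functional assay (aorta) with Oryctolagus cuniculus as the target (a lower number here means tighter binding, a higher number weaker binding), compound 1 (`CCCCc1nc2cccnc2n1Cc1cc(Cl)c(O)c(Cl)c1`) gives 63.1 nM and compound 2 (`CCCc1nc2cccnc2n1Cc1cc(Cl)c(O)c(Cl)c1`) gives 31.6 nM as the first two readings. Compound 3 (`CCCCc1nc2c(C)ccnc2n1Cc1cc(Cl)c(O)c(Cl)c1`) gives 10 nM as the lowest number of the three, and both others lie beyond the scatter from it. Compound 4 (`CCCc1nc2c(C)ccnc2n1Cc1cc(Cl)c(O)c(Cl)c1`) is still unmeasured. It differs from compound 3 by hydrogen in place of methyl on a saturated chain carbon, three bonds along the chain from an aromatic carbon and so turns butyl to propyl while keeping the methyl on an aromatic carbon.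

Among the compounds with values here, the one measured step of the same kind is a 2.0-fold lower number from compound 1 to compound 2 (0.30 log units; within the scatter) and comes from a pair without that aromatic methyl. It is small, and this single pair gives only a weak lean toward a lower number. The other measured step is a 6.3-fold lower number from compound 1 to compound 3 (0.80 log units; beyond the scatter) and adds the aromatic methyl. Compound 4 keeps that methyl, so this step sets the starting level and not the size of the change. Whether the two changes add up independently has not been tested. The expected step is a 1.7-fold lower number from compound 3 to compound 4 (0.22 log units; within the scatter) in this assay and may well stay within the scatter. Compound 4 is therefore estimated at 6 nM (expected range 2.5 nM to 15 nM).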

Compound 4, dissociation constant: 1.26 nM
Estimate against measurement, compound 4: 4.8-fold (0.68 log units) above; the measured number lies below the stated range.
By their numbers in this assay, from the lowest: compound 4; then compound 3; then compounds 2 and 1 (each within the scatter of the next).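

In this assay the change from butyl to propyl gives a 7.9-fold lower number from compound 3 to compound 4 (0.90 log units; beyond the scatter) with the aromatic methyl present, so its size depends on the core that carries it: the same change on two cores in this assay, a 2.0-fold lower number (0.30 log units; within the scatter) from compound 1 to compound 2 and a 7.9-fold lower number (0.90 log units; beyond the scatter) from compound 3 to compound 4, 4.0-fold (0.60 log units) apart, beyond the scatter of two such steps. Seen from the other change, methyl in place of hydrogen on an aromatic carbon gives a 25-fold lower number from compound 2 to compound 4 (1.40 log units; beyond the scatter) on the propyl chain and is larger there than on the butyl chain: the same change on two cores in this assay, a 6.3-fold lower number (0.80 log units; beyond the scatter) from compound 1 to compound 3 and a 25-fold lower number (1.40 log units; beyond the scatter) from compound 2 to compound 4, 4.0-fold (0.60 log units) apart, beyond the scatter of two such steps. The two changes therefore do not add independently across these four compounds, and a step measured on the core without the aromatic methyl is a poor guide to the same step on the core with it.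

The chain is shown only as butyl or propyl, so it remains open whether ethyl or pentyl on the core of compound 4 would continue the trend or reverse it. From the compounds shown here alone, it also remains open whether this dependence on the aromatic methyl is specific to methyl or would also appear with ethyl or chloro on that aromatic carbon.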